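The compounds below may be only part of what the source reports. "The series", "measured", "known", "first", "only" and "open" are said of these compounds alone.

Measured so far:
- compound 1 `CN(C)CCN(CCN(C)C)c1cccc(C(=O)N2CCc3ccc(OS(N)(=O)=O)cc3C2)c1` — in an assay on HEK293 cells for inhibition of Steryl-sulfatase (Homo sapiens), tested at 1 uM (on this read-out lower numbers stand for a weaker effect and higher numbers for a stronger effect at the one concentration tested), compound 1 gives 17.1%
- compound 2 `CCN(Cc1cccc(Br)c1)c1ccc(C(=O)N2CCc3ccc(OS(N)(=O)=O)cc3C2)cc1` — compound 2 gives 97.2%
- compound 3 `NS(=O)(=O)Oc1ccc2c(c1)CN(C(=O)c1cccc(N3CCN(c4ncccn4)CC3)c1)CC2` — compound 3 gives 24.4%

Compound 2 stands highest of the three numbers. The nearest is compound 3, whose read-out lies well below it, beyond the scatter; compound 1 lies lower still, also beyond the scatter. The three measured compounds differ from one another in more than one place, so no single structural step within the measured set can be read off, and no cause for the gaps between them is given here.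

Compound 4 `CCN(Cc1ccc(Br)cc1)c1ccc(C(=O)N2CCc3ccc(OS(N)(=O)=O)cc3C2)cc1` is the next entry. It differs from compound 2 only by 4-bromophenyl in place of 3-bromophenyl on a saturated chain carbon bound to a nitrogen on an aromatic ring. The bromine-bearing ring is kept, the ethyl on the nitrogen is kept, and the rest of the molecule is unchanged.

For this assay the step from compound 2 to compound 4 is expected to be small, with no change beyond the scatter in either direction, because compound 2 already gives 97.2%, leaving little room upward. The expected step is a number 4.2 percentage points lower from compound 2 to compound 4 (within the scatter). Compound 4 is estimated at 93%, within a range from 78% to 99%.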

Compound 4, a percentage reported as inhibition, at one concentration (the size of the read-out at that concentration, not a potency): 95.9%
Estimate against measurement, compound 4: 2.9 percentage points below, and the stated range covers the measured number.
By their numbers in this assay, from the lowest: compounds 1 and 3 (each within the scatter of the next); then compounds 4 and 2 (each within the scatter of the next).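

In this assay, 4-bromophenyl in place of 3-bromophenyl on a saturated chain carbon bound to a nitrogen on an aromatic ring gives a number 1.3 percentage points lower from compound 2 to compound 4 (within the scatter). Going by these compounds alone, this is the first step that can be read at one place, and it shows that the read-out at this single concentration does not distinguish the two bromine placements: compound 2 gives 97.2% and compound 4 gives 95.9%, both near the top of the percentage scale, where a difference in potency could go unseen. Nothing measured here bears on why the two compounds read alike.

The compounds shown leave open whether the two isomers would separate in a measurement across several concentrations, and whether the bromine is needed at all, which a plain phenyl or a chlorophenyl at the same place would test. On these data alone, the role of the ethyl on the nitrogen also stays open, and a methyl or a longer chain there would give the next one-place comparison.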